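Phenyl in Place of Butoxy on the Shared Core

The source may hold more compounds than are shown below. What is called first, only, known or untested is meant among the compounds shown, and "the series" means these compounds.

Three compounds have been measured in a functional assay on A549 cells (Homo sapiens) for antiproliferative activity, read by MTT assay, with a stated time of 48 h; on this read-out higher numbers stand for weaker inhibition and lower numbers for stronger inhibition:
- compound 1 `COc1ccc(/C=C/c2cc(OC)cc(OC)c2/C=C/C(=O)c2ccc(C)cc2)cc1` gives 3.6 ug/mL
- compound 2 `CCCCOc1ccc(C(=O)/C=C/c2c(/C=C/c3ccc(OC)cc3)cc(OC)cc2OC)cc1` gives 8.7 ug/mL
- compound 3 `COc1ccc(/C=C/c2cc(OC)cc(OC)c2/C=C/C(=O)c2ccc(N)cc2)cc1` gives 3.8 ug/mL

Compound 2 stands at the highest number of the three, and both of its gaps to the others lie beyond the usual scatter. The measured steps show this: putting butoxy in place of methyl gave a 2.4-fold higher number from compound 1 to compound 2 (0.38 log units; beyond the scatter), and putting amino in place of butoxy gave a 2.3-fold lower number from compound 2 to compound 3 (0.36 log units; beyond the scatter), while the remaining pair, compound 1 to compound 3, shows a 1.1-fold higher number from compound 1 to compound 3 (0.02 log units; within the scatter). In short, on this group both alternatives to butoxy so far sit at a lower number in this assay.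

Compound 4 `COc1ccc(/C=C/c2cc(OC)cc(OC)c2/C=C/C(=O)c2ccc(-c3ccccc3)cc2)cc1` differs from compound 2 by phenyl in place of butoxy on an aromatic carbon. Among the compounds with values here, no measured compound carries a ring at this position, so the only guidance is that each replacement of butoxy seen so far was a modest move down. The step from compound 2 to compound 4 is therefore expected to be a modest lowering, a 1.9-fold lower number from compound 2 to compound 4 (0.29 log units; within the scatter), though a ring could behave differently from methyl or amino. Compound 4 is estimated at 4.5 ug/mL in this assay, within a range of 2 ug/mL to 10 ug/mL.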

Compound 4, half-maximal inhibitory concentration: 4.6 ug/mL
Estimate against measurement, compound 4: 1.0-fold (0.01 log units) below, and the stated range covers the measured number.
By their numbers in this assay, from the lowest: compounds 1, 3, 4 and 2 (each within the scatter of the next, the first and the last beyond it).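

In this assay, a ring can stand at this position on the shared core without a clear shift: the steps of a 1.2-fold higher number from compound 3 to compound 4 (0.08 log units; within the scatter) and a 1.3-fold higher number from compound 1 to compound 4 (0.11 log units; within the scatter) both stay within the usual scatter, so phenyl cannot be told apart from amino or methyl here. The step of a 1.9-fold lower number from compound 2 to compound 4 (0.28 log units; within the scatter) also stays within the scatter, so phenyl, unlike methyl and amino, does not clearly separate from butoxy, and compound 2 is no longer set apart from every other compound in the series. No measurement shown here offers an explanation for how these groups compare at this position.

Still open, on these data alone, is whether the gap that separates compound 2 from compound 1 and compound 3 goes with the length of the butoxy chain or with its oxygen, and a methoxy group and a plain butyl chain at this position would help to tell these apart. Also open is how a carboxylic acid would compare here, since every group shown so far at this position lacks one.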